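Swapping trifluoromethyl for fluoro on a diaryl urea

A few compounds are considered here, and "the series" means these few. Any claim that something is new, unique, unknown or untested is made for them only; others in the source may bear on it.

Compounds measured so far:
- Compound 1, `Cc1cc(NC(=O)Nc2ccc(C)c(Cl)c2)c2ccccc2n1`, gives > 25000 nM in an ADME assay on BJ cells (Homo sapiens) for cytotoxicity, with a stated time of 72 h; a higher number here means that more compound is needed for the effect, a lower number that less compound is needed.
- Compound 2, `Cc1cc(NC(=O)Nc2ccc(C(=O)O)cc2)c2ccccc2n1`, gives > 25000 nM in this assay.
- Compound 3, `Cc1cc(NC(=O)Nc2ccccc2C(F)(F)F)c2ccccc2n1`, gives > 25000 nM in this assay.

All three of these values are limits of this assay, not numbers: the cells were not harmed at the highest amount tested, so the true value lies beyond it. Compound 3 therefore stands at the limit, exactly where its two companions stand, and nothing separates it from them. The common picture is stated in one line: the limit of > 25000 nM in this assay, at which 3 of the 3 values shown sit. Compounds 1, 2 and 3 differ only in the substituents on one aromatic ring of the urea, and none of these differences moves the read-out off the limit.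

Compound 4, `Cc1cc(NC(=O)Nc2ccccc2F)c2ccccc2n1`, is the next compound to be measured in this assay. It differs from compound 3 by a small change: fluoro in place of trifluoromethyl on an aromatic carbon. With three compounds of the same core all sitting at the limit, and compound 4 keeping that core, a step beyond the scatter is not expected. Compound 4 is therefore expected to sit at 30000 nM, within a range of 15000 nM to 60000 nM, which means an expected step that the limit leaves unreadable from compound 3 to compound 4, most likely reported again as a limit only.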

Compound 4, half-maximal effective concentration: > 25000 nM
Compound 4: only a limit was reported; the forecaster's own chance of this, stated with the estimate: 85%; the middle value does not contradict the limit.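

Compound 3 and compound 4 both give only a limit, not a number, so no step can be read between them: the limit of > 25000 nM in this assay, at which 4 of the 4 values shown sit. What stays open is the concentration at which any of these compounds would reach the half-maximal effect in this assay and whether fluoro and trifluoromethyl differ there at all.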